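Ring Swap at the Aryl Ether of an Aminoquinoline Series

This account rests on a few compounds, and the source may have more. Where it says the series, first, only, none or still open, it means among the compounds named here.

Of the compounds shown here, three sharing one core have been measured in an assay on cells with melanin-concentrating hormone receptor 1 (Homo sapiens) as the target, read by radioligand binding; on this read-out lower numbers stand for stronger inhibition and higher numbers for weaker inhibition. Compound 1 `Nc1ccc2cccc(OCC3CCCC3)c2n1` gives 53 nM. Compound 2 `CCCOc1cccc2ccc(N)nc12` gives 1100 nM, and compound 3 `CC(C)(C)CCOc1cccc2ccc(N)nc12` gives 201 nM. Compound 3 therefore stands second of the three, separated from compound 1 by a 3.8-fold higher number from compound 1 to compound 3 (0.58 log units; beyond the scatter) and from compound 2 by a 5.5-fold lower number from compound 2 to compound 3 (0.74 log units; beyond the scatter); the widest gap in the set is a 21-fold higher number from compound 1 to compound 2 (1.32 log units; beyond the scatter).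

Compound 4 `CC1CC1COc1cccc2ccc(N)nc12` is the unmeasured neighbour of compound 3, differing by 2-methylcyclopropyl in place of neopentyl on a saturated chain carbon bound to an oxygen on an aromatic ring. Within the data shown here, two measured steps bear on this change. The step of a 3.8-fold higher number from compound 1 to compound 3 (0.58 log units; beyond the scatter) shows that taking the ring away at this position costs potency in a modest way, and a 5.5-fold lower number from compound 2 to compound 3 (0.74 log units; beyond the scatter) shows that adding bulk two bonds along the chain recovers part of it. Compound 4 brings a ring back at the same saturated chain carbon, although a smaller one than in compound 1, with a methyl on it. On this basis compound 4 is expected to land between compound 3 and compound 1, with the step from compound 3 estimated as a 1.3-fold lower number from compound 3 to compound 4 (0.13 log units; within the scatter), a change that may not exceed the scatter. The estimate for compound 4 in this assay is 150 nM, with a range from 50 nM to 450 nM.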

Compound 4, half-maximal inhibitory concentration: 1640 nM
Beside the measured number, compound 4's estimate is 11-fold (1.04 log units) below it; the measured number lies above the stated range.
By their numbers in this assay, from the lowest: compound 1; then compound 3; then compounds 2 and 4 (each within the scatter of the next).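

In this assay, putting a ring back on the saturated chain carbon bound to an oxygen on an aromatic ring did not by itself restore potency: 2-methylcyclopropyl in place of neopentyl gave an 8.2-fold higher number from compound 3 to compound 4 (0.91 log units; beyond the scatter), so the ringless neopentyl group outperformed this three-membered ring, and the earlier reading of the cyclopentyl ring as an advantage does not extend to every ring. The 2-methylcyclopropyl group in place of ethyl gave a 1.5-fold higher number from compound 2 to compound 4 (0.17 log units; within the scatter), which leaves these two compounds indistinguishable, whereas the same group in place of cyclopentyl gave a 31-fold higher number from compound 1 to compound 4 (1.49 log units; beyond the scatter), so the ring of compound 1 cannot be replaced by this smaller one without a large loss. No supporting evidence is available to explain why this group behaves as it does.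

Compound 4 differs from compound 1 in both ring size and the methyl on its ring, so the compounds shown do not separate these two changes. An unsubstituted cyclopropyl, a cyclobutyl or a cyclohexyl ring at this place would be needed to show how potency follows ring size.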